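This account rests on a few compounds, and the source may have more. Where it says the series, first, only, none or still open, it means among the compounds named here.

Compounds measured so far:
- Compound 1, `CCCCOC(=O)Nc1cc2nc(C3CCCCC3)[nH]c2cc1N(C)C`: in an ADME assay on Vero cells (Chlorocebus sabaeus) for cytotoxicity, read by resazurin assay, with a stated time of 3 days (a lower number here means a stronger inhibitor, a higher number a weaker inhibitor), compound 1 gives > 100 ug/mL, which is a limit of the assay rather than a number.
- Compound 2, `CCCN(CCC)c1cc2[nH]c(C3CCCCC3)nc2cc1NC(=O)c1ccccc1`: in this assay compound 2 gives > 100 ug/mL, again only a limit.
- Compound 3, `CCCCOC(=O)Nc1cc2nc(C3CCCCC3)[nH]c2cc1N(CCC)CCC`: in this assay compound 3 gives > 100 ug/mL, once more a limit.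

Compound 3 therefore stands only at a limit, and the same holds for the two compounds that differ from it in one place; this is the limit of > 100 ug/mL in this assay, at which 3 of the 3 values shown sit. Two single-point changes lead to compound 3 from measured neighbours: a step that the two limits leave unreadable from compound 1 to compound 3 and a step that the two limits leave unreadable from compound 2 to compound 3. Going by the values given here, neither of them shows a size, since both of their ends are limits, so nothing measured so far tells how far any one of these changes moves the read-out.

The unmeasured compound 4, `CCCCOC(=O)Nc1cc2nc(C3CCCCC3)[nH]c2cc1N(CC)CCN(C)C`, differs from compound 3 in one place: (2-(dimethylamino)ethyl)(ethyl)amino in place of dipropylamino on an aromatic carbon. Among the compounds with values here, no measured step bears readably on this change. Because the limit of > 100 ug/mL in this assay, at which 3 of the 3 values shown sit, puts every value shown at the same limit, the expectation is that compound 4 will show no step beyond the scatter, that is a number no higher from compound 3 to compound 4 (the limit leaves the size open), and will most likely again be reported as a limit. The estimate for compound 4 is 100 ug/mL, with a range from 50 ug/mL to 200 ug/mL.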

Compound 4, half-maximal inhibitory concentration: > 100 ug/mL
Compound 4: only a limit was reported (the forecaster's own chance of this, stated with the estimate: 80%); the middle value lies on the limit itself.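

In this assay compound 4 gives > 100 ug/mL as a limit only. The changes leading from compound 3 and from compound 1 to compound 4 cannot be read as steps, because all the values stand at one limit: the limit of > 100 ug/mL in this assay, at which 4 of the 4 values shown sit. The compounds shown leave open how far any of these changes moves the read-out.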